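The source may hold more compounds than are shown below. What is called first, only, known or untested is meant among the compounds shown, and "the series" means these compounds.

Compound 1 `CCCNc1nnc(SCC(=O)N(Cc2cccc([N+](=O)[O-])c2)c2ccc(F)cc2)s1` is the point of departure. Among the measured compounds shown here, in an assay on isolated protein for inhibition of Amine oxidase [flavin-containing] B (Homo sapiens), read by fluorescence and Amplex Red, with a stated time of 30 min, tested at 100 uM (on this read-out higher numbers stand for a stronger effect at the one concentration tested and lower numbers for a weaker effect), compound 1 gives 26.8%, and the only other number belongs to compound 2 `CCNc1nnc(SCC(=O)N(Cc2cccc([N+](=O)[O-])c2)c2ccc(F)cc2)s1`, which in this assay gives 22.4%. The step between them, a number 4.4 percentage points lower from compound 1 to compound 2 (within the scatter), lies within the scatter, so the two numbers cannot be told apart, and compound 1 simply stands alongside compound 2 rather than apart from it.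

Compound 3 `CC(C)Nc1nnc(SCC(=O)N(Cc2cccc([N+](=O)[O-])c2)c2ccc(F)cc2)s1` has not yet been measured. It differs from compound 1 by isopropyl in place of propyl on a nitrogen on an aromatic ring. For the measured compounds named here, only one measured step has any bearing on this change: a number 4.4 percentage points lower from compound 1 to compound 2 (within the scatter), which also alters the chain on a nitrogen on an aromatic ring and left the read-out where it was. Because a number 4.4 percentage points lower from compound 1 to compound 2 (within the scatter) stayed within the scatter, the step expected for compound 3, a number 1.8 percentage points lower from compound 1 to compound 3 (within the scatter), is none beyond the scatter either. Compound 3 is therefore estimated to give 25% in this assay, with a range expected from 12% to 38%.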

Compound 3, a percentage reported as inhibition, at one concentration (the size of the read-out at that concentration, not a potency): 28.5%
For compound 3 the middle estimate is 3.5 percentage points below the measured one; the measured number falls inside the stated range.
By their numbers in this assay, from the lowest: compounds 2, 1 and 3 (each within the scatter of the next).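

In this assay, the step of a number 1.7 percentage points higher from compound 1 to compound 3 (within the scatter) shows that rearranging the same three carbons on the nitrogen, from propyl to isopropyl, does not separate the two compounds, whereas the earlier pair had tested only the removal of a methyl from the chain. The step of a number 6.1 percentage points higher from compound 2 to compound 3 (within the scatter), with a methyl in place of hydrogen on the chain carbon bound to that nitrogen, also stays within the scatter, so the ethyl, propyl and isopropyl compounds cannot be told apart here, whether the chain differs in length or in shape. Nothing is available that would explain this flat result.

On these data alone, these three compounds span only small saturated chains at one place, so it remains open whether a free amino group, a cyclopropyl, a much longer chain such as hexyl or a benzyl on the same nitrogen would move the read-out beyond the scatter. As far as these compounds go, it also remains open whether the three would stay together in a full concentration series, as the single concentration gives a size of effect rather than a potency, and the rest of the shared core stays unchanged throughout.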